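The compounds below may be only part of what the source reports. "The series", "measured", "known", "first", "only" and "open" are said of these compounds alone.

Compound 1 `C=C/C=C\[C@H](C)[C@H](OC(N)=O)[C@@H](C)[C@H](O)[C@@H](C)C/C(C)=C\[C@H](C)[C@@H](O)[C@@H](C)/C=C\CCc1cccc(O)c1` is the reference point of this small set. In a functional assay on SK-OV-3 cells (Homo sapiens) for cytotoxicity (on this read-out higher numbers stand for weaker inhibition and lower numbers for stronger inhibition), compound 1 gives 40 nM, the lowest number of the three measured compounds, and so the strongest inhibitor among them. Two measured neighbours carry other rings at the same chain position: compound 2 `C=C/C=C\[C@H](C)[C@H](OC(N)=O)[C@@H](C)[C@H](O)[C@@H](C)C/C(C)=C\[C@H](C)[C@@H](O)[C@@H](C)/C=C\CCc1ccc(C)c(F)c1` gives 1000 nM, and compound 3 `C=C/C=C\[C@H](C)[C@H](OC(N)=O)[C@@H](C)[C@H](O)[C@@H](C)C/C(C)=C\[C@H](C)[C@@H](O)[C@@H](C)/C=C\CCc1cc(F)cc(F)c1` gives 360 nM. Both replacements weakened inhibition: a 25-fold higher number from compound 1 to compound 2 (1.40 log units; beyond the scatter) and a 9.0-fold higher number from compound 1 to compound 3 (0.95 log units; beyond the scatter). Compound 4 `C=C/C=C\[C@H](C)[C@H](OC(N)=O)[C@@H](C)[C@H](O)[C@@H](C)C/C(C)=C\[C@H](C)[C@@H](O)[C@@H](C)/C=C\CCc1sccc1C` is not yet measured; it differs from compound 1 by 3-methylthiophen-2-yl in place of 3-hydroxyphenyl on a saturated chain carbon, two bonds along the chain from a double-bonded chain carbon. Since every measured step away from the 3-hydroxyphenyl group raised the number well beyond the scatter, a weakening of similar size is expected here too. Compound 4 is therefore expected to give 400 nM in this assay, within a range from 120 nM to 1500 nM, which amounts to an expected 10-fold higher number from compound 1 to compound 4 (1.00 log units; beyond the scatter).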

Compound 4, half-maximal inhibitory concentration: 370 nM
The estimate for compound 4 lay 1.1-fold (0.03 log units) above the measured number; measured number inside the range.
By their numbers in this assay, from the lowest: compound 1; then compounds 3 and 4 (each within the scatter of the next); then compound 2.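

Swapping the six-membered ring for a five-membered aromatic ring, 3-methylthiophen-2-yl, gives a 9.3-fold higher number from compound 1 to compound 4 (0.97 log units; beyond the scatter) in place of 3-hydroxyphenyl, so the loss at this position is not confined to substituted phenyl rings. Against the other replacements, this group gives a 1.0-fold higher number from compound 3 to compound 4 (0.01 log units; within the scatter) and a 2.7-fold lower number from compound 2 to compound 4 (0.43 log units; beyond the scatter) at the same position, so a change of ring size does not by itself decide the outcome here. On these data alone, whether the hydroxyl of compound 1 alone accounts for its lower number stays open, as does how a 3-aminophenyl or 3-carboxyphenyl group would behave at this position. No data here explain these steps.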